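Swapping the ester for a propargyl ether in compound 3

The source may hold more compounds than are shown below. What is called first, only, known or untested is meant among the compounds shown, and "the series" means these compounds.

Measured so far in a functional assay on the whole organism with Scenedesmus acutus as the target; on this read-out higher numbers stand for weaker inhibition and lower numbers for stronger inhibition:
compound 1 `COC(=O)c1cc(N2C(=O)C3=C(CCCC3)C2=O)ccc1Cl` gives 2000 nM
compound 2 `COC(=O)c1cc(N2C(=O)C3=C(CCCC3)C2=O)c(F)cc1Cl` gives 110 nM

Compound 2 stands lowest of the two, with compound 1 separated by an 18-fold lower number from compound 1 to compound 2 (1.26 log units; beyond the scatter). Compound 3 `C#CCOc1cc(N2C(=O)C3=C(CCCC3)C2=O)c(F)cc1Cl` differs from compound 2 by propargyloxy in place of methoxycarbonyl on an aromatic carbon. Within the data shown here, no measured step touches this kind of change; the only measured step concerns a fluoro group and so gives no guide to the size or direction here. The step expected for compound 3 in this assay is therefore uncertain, a 1.8-fold lower number from compound 2 to compound 3 (0.26 log units; within the scatter). Compound 3 is estimated at 60 nM, within a range of 15 nM to 250 nM.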

Compound 3, half-maximal inhibitory concentration: 15.9 nM
For compound 3 the middle estimate is 3.8-fold (0.58 log units) above the measured one, within the range that was stated.
By their numbers in this assay, from the lowest: compound 3; then compound 2; then compound 1.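

At the aromatic carbon ortho to a chloro group and para to a fluoro group, methoxycarbonyl is not required for activity: in this assay, propargyloxy in its place gives a 6.9-fold lower number from compound 2 to compound 3 (0.84 log units; beyond the scatter). The heavy-atom count stays the same, while a triple bond replaces a double bond and one hydrogen-bond acceptor is lost. Nothing available explains this gain.

On these data alone, it remains open whether the gain depends on the triple bond, as a propoxy group at this carbon could test. Also open, as far as these compounds go, is whether the fluoro group matters as much alongside propargyloxy as alongside methoxycarbonyl.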